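Swapping 3,4-difluorophenyl for pentyl on the shared core

A few compounds are considered here, and "the series" means these few. Any claim that something is new, unique, unknown or untested is made for them only; others in the source may bear on it.

Measured in a functional assay on PC-3 cells (Homo sapiens) for cytotoxicity, read by WST assay, with a stated time of 72 h; on this read-out lower numbers stand for stronger inhibition and higher numbers for weaker inhibition:
Compound 1 `Cc1ccc(C2(c3ccc(O)cc3)C(=O)Nc3c2ccc(F)c3F)cc1`: 0.8 nM
Compound 2 `COc1ccc(C2(c3ccc(O)cc3)C(=O)Nc3c2ccc(F)c3F)cc1`: 2 nM; 2.2 nM; > 1000 nM (3 entries)
Compound 3 `O=C1Nc2c(ccc(F)c2F)C1(c1ccc(O)cc1)c1ccc(F)c(F)c1`: 19 nM

One entry of compound 2 is a limit of the assay and not a number. Compound 3 stands highest of the two compounds with a single number, at 19 nM. Compound 4 `CCCCCC1(c2ccc(O)cc2)C(=O)Nc2c1ccc(F)c2F`, not yet measured, carries pentyl in place of 3,4-difluorophenyl on a saturated ring carbon, (pentyl in place of 3,4-difluorophenyl on a saturated ring carbon). For the measured compounds named here, the one measured step at that carbon, a 24-fold higher number from compound 1 to compound 3 (1.38 log units; beyond the scatter), is large in this assay, so another rise in the number is expected here, although no compound with a chain there has been measured. The estimated step is a 6.3-fold higher number from compound 3 to compound 4 (0.80 log units; beyond the scatter). For compound 4 the estimated value is 120 nM, with an expected range from 20 nM to 700 nM.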

Compound 4, half-maximal inhibitory concentration: 1.1 nM
Estimate against measurement, compound 4: 110-fold (2.04 log units) above; the measured number lies below the stated range.
By their numbers in this assay, from the lowest: compounds 1 and 4 (each within the scatter of the next); then compound 3.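

In this assay, pentyl in place of 3,4-difluorophenyl on this saturated ring carbon gives a large change (a 17-fold lower number from compound 3 to compound 4 (1.24 log units; beyond the scatter)), so a low number here does not require an aromatic ring at this position. Pentyl in place of 4-methylphenyl gives a change within the scatter (a 1.4-fold higher number from compound 1 to compound 4 (0.14 log units; within the scatter)), so the high number of compound 3 does not hold for every group tried at this carbon.

The compounds shown leave open whether a shorter chain such as propyl, a longer chain such as octyl, or a chain ending in an amine would keep the number this low. Nothing shown gives a cause for either step.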